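The source may report more compounds than this note shows. Statements on the series, on what has been measured and on what is new or still open speak of the compounds shown alone.

Compound 1 `CCOC(=O)c1c(-c2cccc(C(F)(F)F)c2)csc1N` gives 9.4 uM in a functional assay on CHO-K1 cells for agonist activity at adenosine receptor A1 (Homo sapiens), read by GTPgammaS binding; on this read-out lower numbers stand for an effect already at smaller amounts and higher numbers for an effect only at larger amounts of compound.
Compound 2 `COc1ccc(-c2sc(N)c(C(=O)c3ccccc3)c2-c2cccc(C(F)(F)F)c2)cc1` gives a limit of the assay, > 10 uM.
Compound 3 `CCOC(=O)c1c(N)sc(-c2ccc([N+](=O)[O-])cc2)c1-c1cccc(C(F)(F)F)c1` gives a limit of the assay, > 10 uM.

Compound 3 thus stands at the limit of > 10 uM in this assay, at which 2 of the 3 values shown sit, and no number places it against the others. Within the data shown here, the single measured step, an at least 1.0-fold higher number from compound 1 to compound 3 (0.02 log units; that floor lies within the scatter), is itself only a floor and gives no direction for attaching the 4-nitrophenyl group.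

Compound 4 `CCOC(=O)c1c(N)sc(-c2ccc(OC)cc2)c1-c1cccc(C(F)(F)F)c1` differs from compound 3 by methoxy in place of nitro on an aromatic carbon. Among the measured compounds shown here, no measured step exchanges these two groups on this core. Compound 2 carries the 4-methoxyphenyl group of compound 4 together with a different substituent on the core and likewise stops at the limit, which is the only pointer available for the methoxy group in this assay. With compound 3 at the limit and compound 2 at the limit, the expected step that the limit leaves unreadable from compound 3 to compound 4 is none beyond the scatter, and a limit rather than a number is the more likely read-out. Compound 4 is estimated at 15 uM, with a range from 4 uM to 60 uM.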

Compound 4, concentration for half-maximal effect: > 10 uM
Compound 4: a limit, no number (the forecaster's own chance of this, stated with the estimate: 65%); the middle value is on the limit's open side.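

In this assay compound 4 gives > 10 uM, which is a limit and not a number. Attaching the 4-methoxyphenyl group gives an at least 1.0-fold higher number from compound 1 to compound 4 (0.02 log units; that floor lies within the scatter), so this change, like the one to the 4-nitrophenyl group, has no readable direction. The exchange of methoxy for nitro and that of ethoxy for phenyl on a carbonyl carbon cannot be read, and with a methoxy as well as a nitro group on this phenyl ring, the series now gathers at one end of the read-out: the limit of > 10 uM in this assay, at which 3 of the 4 values shown sit.

Going by these compounds, it remains open whether any substituent on this aromatic carbon gives a number in this assay, for instance a methyl group, a bromine atom or an unsubstituted phenyl ring. On these data alone, it is equally open whether a different group on the phenyl ring, such as an amine or a carboxylic acid in place of methoxy, would separate from the limit and so make the effect of this position readable.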